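The compounds below may be only part of what the source reports. "The series", "measured", "known", "first", "only" and "open" are said of these compounds alone.

Measured compounds in an assay on IM-9 cells for displacement of a labelled ligand from Substance-P receptor (Homo sapiens), read by scintillation counting, with a stated time of 30 min; on this read-out higher numbers stand for weaker inhibition and lower numbers for stronger inhibition:
compound 1 `CCc1ccccc1[C@H]1CN(C(=O)C2CCN(C(C)=O)CC2)CC[C@@H]1C(=O)N(C)Cc1cc(C(F)(F)F)cc(C(F)(F)F)c1` gives 0.064 nM
compound 2 `CC(=O)N1CCC(C(=O)N2CC[C@H](C(=O)N(C)Cc3cc(C(F)(F)F)cc(C(F)(F)F)c3)[C@@H](c3ccc(F)cc3C)C2)CC1` gives 0.047 nM
compound 3 `CC(=O)N1CCC(C(=O)N2CC[C@H](C(=O)N(C)Cc3cc(C(F)(F)F)cc(C(F)(F)F)c3)[C@@H](c3ccccc3C)C2)CC1` gives 0.032 nM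

On these numbers compound 2 sits between the other two; the step of a 1.4-fold lower number from compound 1 to compound 2 (0.13 log units; within the scatter) and the step of a 1.5-fold lower number from compound 2 to compound 3 (0.17 log units; within the scatter) are both within the scatter, as is a 2.0-fold lower number from compound 1 to compound 3 (0.30 log units; within the scatter). All three changes so far concern the aryl group on the saturated ring carbon, and none of them shifts the read-out beyond noise.

Compound 4 `CC(=O)NCC(=O)N1CC[C@H](C(=O)N(C)Cc2cc(C(F)(F)F)cc(C(F)(F)F)c2)[C@@H](c2ccc(F)cc2C)C1` differs from compound 2 elsewhere: acetamidomethyl in place of 1-acetylpiperidin-4-yl on a carbonyl carbon. Among the measured compounds shown here, no measured step touches this part of the shared core, so the three steps above give no direct guide; they only show that this core tolerates small edits at the aryl end. Replacing the ring-bearing acyl group by a shorter, donor-bearing one is a larger change than any measured here, and the expectation for compound 4 in this assay is therefore a weaker number, estimated at 0.2 nM (range 0.04 nM to 1 nM), a step of a 4.3-fold higher number from compound 2 to compound 4 (0.63 log units; beyond the scatter), with wide uncertainty in both directions.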

Compound 4, half-maximal inhibitory concentration: 0.043 nM
Compound 4: middle estimate off by 4.7-fold (0.67 log units), on the high side; the measured number falls inside the stated range.
By their numbers in this assay, from the lowest: compounds 3, 4, 2 and 1 (each within the scatter of the next).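

In this assay, acetamidomethyl in place of 1-acetylpiperidin-4-yl on a carbonyl carbon gives a 1.1-fold lower number from compound 2 to compound 4 (0.04 log units; within the scatter), so the tolerance to small edits seen at the aryl end now also extends to this separate position and to a much larger edit. Within this single pair, the group loses its six-membered ring and gains a hydrogen-bond donor, yet the read-out does not move beyond the scatter, so the ring is not needed to keep the number in this range. Nothing in hand bears on why the read-out holds here.

Still open, from the compounds shown here alone, is whether a primary amine, a carboxylic acid or a longer chain on this carbonyl carbon would keep the read-out in the same range. Also open, going by these compounds, is whether the same swap holds with 2-ethylphenyl in place of 4-fluoro-2-methylphenyl on the saturated ring carbon, as the change rests on one pair only.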